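The source may report more compounds than this note shows. Statements on the series, on what has been measured and on what is new or still open speak of the compounds shown alone.

Series notes. Compound 1 `Fc1ccc(-c2nn3ccc(N4CCCC4)cc3c2-c2ccnc(NC3CCCC3)n2)cc1` in an ADME assay on Vero cells (Chlorocebus sabaeus) for cytotoxicity (a lower number here means that less compound is tolerated, a higher number that more compound is tolerated), reaches only the limit of the assay, > 40000 nM. Compound 2 `Fc1ccc(-c2nn3c(NC4CCCC4)cc(NC4CCCC4)cc3c2-c2ccnc(NC3CCCC3)n2)cc1` likewise gives a limit and not a number, > 40000 nM. Compound 3 `Fc1ccc(-c2nn3c(NC4CC4)cc(Cl)cc3c2-c2ccnc(NC3CCCC3)n2)cc1` also stops at the limit in this assay, > 40000 nM. Within the data shown here, the measured compounds differ in more than one place, so no single step between them is available; their common standing is the limit of > 40000 nM in this assay, at which 3 of the 3 values shown sit. Compound 4 `CN(C)c1cc(Cl)cc2c(-c3ccnc(NC4CCCC4)n3)c(-c3ccc(F)cc3)nn12` differs from compound 3 by dimethylamino in place of cyclopropylamino on an aromatic carbon. Because every value shown rests at the limit (the limit of > 40000 nM in this assay, at which 3 of the 3 values shown sit), no step beyond the scatter is expected in this assay. The expected step is a step that the limit leaves unreadable from compound 3 to compound 4. Compound 4 is estimated at 50000 nM, with a range of 20000 nM to 120000 nM, most likely reported again as a limit.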

Compound 4, half-maximal cytotoxic concentration: > 40000 nM
Compound 4 gave a limit, no number (the forecaster's own chance of this, stated with the estimate: 85%); the middle value does not contradict the limit.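

In this assay compound 3 and compound 4 both rest at the limit, so dimethylamino in place of cyclopropylamino gives no readable step: the limit of > 40000 nM in this assay, at which 4 of the 4 values shown sit. Left open is whether this assay can give any compound of this series a number rather than a limit.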